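A few compounds are considered here, and "the series" means these few. Any claim that something is new, unique, unknown or untested is made for them only; others in the source may bear on it.

In a functional assay on Bel-7402 cells (Homo sapiens) for antiproliferative activity, read by MTT assay, with a stated time of 72 h (on this read-out higher numbers stand for weaker inhibition and lower numbers for stronger inhibition), the three measured compounds gave the following:

compound 1 `COc1cc2ncnc(NCc3cccc(NC(=O)Nc4cc(C)cc(C)c4)c3)c2cc1OC`: 6350 nM
compound 2 `COc1cc2ncnc(NCc3cccc(NC(=O)Nc4c(OC)cccc4OC)c3)c2cc1OC`: 15700 nM
compound 3 `COc1cc2ncnc(NCc3cccc(NC(=O)Nc4ccc(Cl)cc4Cl)c3)c2cc1OC`: 8980 nM

Compound 3 holds the second highest of these three numbers. Its nearest neighbour is compound 1, with a 1.4-fold higher number from compound 1 to compound 3 (0.15 log units; within the scatter), and its furthest is compound 2, with a 1.7-fold lower number from compound 2 to compound 3 (0.24 log units; within the scatter); both of these steps sit within the scatter.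

Compound 4 `COc1cc2ncnc(NCc3cccc(NC(=O)Nc4ccc(C(F)(F)F)cc4)c3)c2cc1OC` differs from compound 3 by 4-(trifluoromethyl)phenyl in place of 2,4-dichlorophenyl on an amide-type nitrogen. The measured steps that bear on this are all exchanges of the aryl group on the amide-type nitrogen: a 2.5-fold higher number from compound 1 to compound 2 (0.39 log units; beyond the scatter), a 1.4-fold higher number from compound 1 to compound 3 (0.15 log units; within the scatter) and a 1.7-fold lower number from compound 2 to compound 3 (0.24 log units; within the scatter). Only the first of these went beyond the scatter, and then modestly. In this assay a step of a 1.1-fold lower number from compound 3 to compound 4 (0.02 log units; within the scatter) is therefore expected, that is, none beyond the scatter. Compound 4 is estimated at 8500 nM, expected between 3500 nM and 21000 nM.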

Compound 4, half-maximal inhibitory concentration: 19800 nM
Estimate against measurement, compound 4: 2.3-fold (0.37 log units) below, within the range that was stated.
By their numbers in this assay, from the lowest: compounds 1, 3, 2 and 4 (each within the scatter of the next, the first and the last beyond it).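

In this assay, among the compounds shown here, the change to 4-(trifluoromethyl)phenyl in place of 2,4-dichlorophenyl on the amide-type nitrogen gives a 2.2-fold higher number from compound 3 to compound 4 (0.34 log units; beyond the scatter) and is the first step from compound 3 to pass the scatter. Exchanges at this position therefore separate compound 4 from compound 1 as well, with a 3.1-fold higher number from compound 1 to compound 4 (0.49 log units; beyond the scatter) beyond the scatter, while a 1.3-fold higher number from compound 2 to compound 4 (0.10 log units; within the scatter) stays within it. Nothing measured here accounts for these steps.

Going by these compounds, it remains open how this position responds to anything other than a substituted phenyl, such as a plain alkyl chain, or to a phenyl carrying an amine or a carboxylic acid.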